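The compounds below may be only part of what the source reports. "The series", "measured", "known", "first", "only" and "open" are said of these compounds alone.

Compounds measured in a functional assay on A549 cells (Homo sapiens) for antiproliferative activity, read by MTT assay, with a stated time of 72 h; on this read-out lower numbers stand for stronger inhibition and higher numbers for weaker inhibition:
- compound 1 `C=CC(=O)Nc1cccc(Oc2nc(Nc3ccn(C)n3)nc3c2CSCC3)c1`: 18600 nM
- compound 2 `C=CC(=O)Nc1cccc(Oc2nc(Nc3cccc(OC)c3)nc3c2CSCC3)c1`: 10100 nM
- compound 3 `C=CC(=O)Nc1cccc(Oc2nc(Nc3ccc(OC)nc3)nc3c2CSCC3)c1`: 14600 nM

The three values lie within the scatter of one another, so compound 3 has no distinct rank. The steps that reach it are a 1.3-fold lower number from compound 1 to compound 3 (0.11 log units; within the scatter) and a 1.4-fold higher number from compound 2 to compound 3 (0.16 log units; within the scatter).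

Next is compound 4 `COc1ccc(Nc2nc3c(c(Oc4cccc(NC(=O)/C=C/C(C)C)c4)n2)CSCC3)cn1`, which keeps the 6-methoxypyridin-3-yl group of compound 3 and carries 3-methylbut-1-en-1-yl in place of vinyl on a carbonyl carbon.

Those two steps and a 1.8-fold lower number from compound 1 to compound 2 (0.27 log units; within the scatter) all exchange the group on a nitrogen on an aromatic ring. None touches the carbonyl carbon, so the data offer no measured size for this change. Among the compounds with values here, with no precedent, no step beyond the scatter is firmly expected, only a weak lean towards a higher number.

The expected step is a 1.4-fold higher number from compound 3 to compound 4 (0.14 log units; within the scatter).

For compound 4 the estimated value is 20000 nM, with an expected range of 7000 nM to 50000 nM.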

Compound 4, half-maximal inhibitory concentration: 24200 nM
Estimate against measurement, compound 4: 1.2-fold (0.08 log units) below; measured number inside the range.
By their numbers in this assay, from the lowest: compounds 2, 3, 1 and 4 (each within the scatter of the next, the first and the last beyond it).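

In this assay, the series now has its first measured change on the carbonyl carbon, and replacing vinyl with 3-methylbut-1-en-1-yl gives a 1.7-fold higher number from compound 3 to compound 4 (0.22 log units; within the scatter). With the 6-methoxypyridin-3-yl group held constant, this single step shows that the longer, branched alkenyl group can sit on this carbonyl carbon without a shift beyond the scatter. Nothing available bears on why the step has this size.

From the compounds shown here alone, the step rests on one pair, so it remains open whether the same exchange would read alike with 3-methoxyphenyl or 1-methyl-1H-pyrazol-3-yl on the aromatic amine nitrogen. Also open, going by these compounds, is how a saturated propyl group or a dimethylaminomethyl-substituted vinyl group on the same carbonyl carbon would compare with vinyl.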